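Compound 3: an open chain replaces the oxolanyl group

This account rests on a few compounds, and the source may have more. Where it says the series, first, only, none or still open, it means among the compounds named here.

Within the data shown here, in a functional assay on A-375 cells (Homo sapiens) for cytotoxicity, read by MTT assay, with a stated time of 72 h (on this read-out higher numbers stand for weaker inhibition and lower numbers for stronger inhibition), compound 3 `O=C1c2c[n+]([O-])c3ccccc3c2C(=O)c2c1c1ccccc1n2Cc1cn([C@@H]2C[C@H](O)[C@@H](CO)O2)nn1` gives 20 nM, the lowest of the three numbers so far and beyond the scatter from both others. Compound 1 `O=C1c2c[n+]([O-])c3ccccc3c2C(=O)c2c1c1ccccc1n2Cc1cn([C@H]2O[C@H](CO)[C@@H](O)[C@H]2O)nn1` gives 340 nM and compound 2 `O=C1c2c[n+]([O-])c3ccccc3c2C(=O)c2c1c1ccccc1n2CCCCn1ccnc1` gives 350 nM, two values within the scatter of each other. The next structure is compound 4 `O=C1c2c[n+]([O-])c3ccccc3c2C(=O)c2c1c1ccccc1n2Cc1cn(C[C@H](O)CO)nn1`, whose difference from compound 3 is 2,3-dihydroxypropyl in place of 4-hydroxy-5-(hydroxymethyl)oxolan-2-yl on an aromatic nitrogen. The ring is thus lost, while the group stays on an aromatic nitrogen of a five-membered aromatic ring with 3 nitrogen.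

Among the measured compounds shown here, one measured step bears on this change. Hydrogen in place of hydroxy on a saturated ring carbon of the same substituent gives a 17-fold lower number from compound 1 to compound 3 (1.23 log units; beyond the scatter), a large step. So a single change in this group has already moved the number in this assay strongly. For the measured compounds named here, no measured compound carries an open chain with hydroxy groups, so that step guides the size only loosely. Compound 1 and compound 2 both differ from compound 3 in this substituent, and both show higher numbers, which points upward.

The expected step is a 6.0-fold higher number from compound 3 to compound 4 (0.78 log units; beyond the scatter), beyond the scatter. For compound 4 the estimated value is 120 nM, with an expected range of 35 nM to 400 nM.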

Compound 4, half-maximal inhibitory concentration: 350 nM
The estimate for compound 4 lay 2.9-fold (0.46 log units) below the measured number, within the range that was stated.
By their numbers in this assay, from the lowest: compound 3; then compounds 1, 2 and 4 (each within the scatter of the next).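

In this assay, replacing the ring with the open chain, 2,3-dihydroxypropyl in place of 4-hydroxy-5-(hydroxymethyl)oxolan-2-yl on an aromatic nitrogen, gives an 18-fold higher number from compound 3 to compound 4 (1.24 log units; beyond the scatter) even though entering and leaving groups have the same count of hydrogen-bond donors. The low number of compound 3 therefore does not follow from that donor count in this substituent, and the open chain does not retain it. Compound 4 instead joins the other two compounds, with a 1.0-fold higher number from compound 1 to compound 4 (0.01 log units; within the scatter) and no change at the digits printed from compound 2 to compound 4 (within the scatter), so the series now holds a single low value against three that lie within the scatter. Compound 1 keeps an oxolanyl ring at this position. The ring alone does not give the low number either.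

Going by these compounds, it remains open whether a 2-hydroxyethyl chain, a 2-aminoethyl chain or an oxolan-2-yl ring with no hydroxy group, on the same aromatic nitrogen, would sit near compound 3 or near the other three. No measurement is available that would account for this result.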